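Ethoxyethyl homologue of the weaker imidazole-substituted xanthine

The source may report more compounds than this note shows. Statements on the series, on what has been measured and on what is new or still open speak of the compounds shown alone.

Compound 1 `CCCn1c(=O)n(CC)c(=O)c2[nH]cnc21` and compound 2 `CCCn1c(=O)n(C)c(=O)c2[nH]cnc21` share a core that carries a hydrogen on the aromatic nitrogen of the five-membered ring; in a functional assay (trachea) with Cavia porcellus as the target (a higher number here means that more compound is needed for the effect, a lower number that less compound is needed), compound 1 gives 1300 nM and compound 2 gives 1600 nM. The change between them, (methyl in place of hydrogen on a saturated chain carbon bound to an aromatic nitrogen), gave a 1.2-fold lower number from compound 2 to compound 1 (0.09 log units; within the scatter). Compound 3 `CCCn1c(=O)n(C)c(=O)c2c1ncn2CCOC` differs from compound 2 by 2-methoxyethyl in place of hydrogen on an aromatic nitrogen, and in this assay compound 3 gives 36100 nM, which is a 23-fold higher number from compound 2 to compound 3 (1.35 log units; beyond the scatter). Compound 4 `CCCn1c(=O)n(C)c(=O)c2c1ncn2CCOCC` is compound 3 with methyl in place of hydrogen on a saturated chain carbon bound to an oxygen on a saturated carbon. This is the same kind of change as from compound 2 to compound 1, but the place differs: there the carbon was bound to an aromatic nitrogen, here it is bound to an oxygen on a saturated carbon. Going by the values given here, only the one earlier step is available, so the expectation rests on it alone: compound 4 is expected to give about 33000 nM in this assay, a step of a 1.1-fold lower number from compound 3 to compound 4 (0.04 log units; within the scatter), because the comparable step a 1.2-fold lower number from compound 2 to compound 1 (0.09 log units; within the scatter) stayed within the scatter. The estimated range for compound 4 runs from 14000 nM to 85000 nM.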

Compound 4, half-maximal effective concentration: 4600 nM
The estimate for compound 4 lay 7.2-fold (0.86 log units) above the measured number, outside the stated range (below it).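

In this assay, methyl in place of hydrogen does not behave as one transferable step in this series: the same change on two cores in this assay, a 1.2-fold lower number (0.09 log units; within the scatter) from compound 2 to compound 1 and a 7.8-fold lower number (0.89 log units; beyond the scatter) from compound 3 to compound 4, 6.4-fold (0.80 log units) apart, beyond the scatter of two such steps On the ether chain the change gives a 7.8-fold lower number from compound 3 to compound 4 (0.89 log units; beyond the scatter), yet 2-ethoxyethyl in place of hydrogen on the aromatic nitrogen still leaves a 2.9-fold higher number from compound 2 to compound 4 (0.46 log units; beyond the scatter), so the ethyl ether does not fully return the number to that of the unsubstituted compound. Going by these compounds alone, with only one pair at each place, and with place and core changing together, these data do not show whether the gap follows the place of the carbon or the core around it, and they give no rule for any further core.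

On these data alone, it remains open whether the lower number continues along the ether series, for example with 2-propoxyethyl or a longer chain on the aromatic nitrogen. Also open, as far as these compounds go, is how a chain ending in an amine or a carboxylic acid would compare with 2-methoxyethyl and 2-ethoxyethyl.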